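Amide nitrogen substituents: from compound 3 to compound 4

This account rests on a few compounds, and the source may have more. Where it says the series, first, only, none or still open, it means among the compounds named here.

Three compounds of this series have a number in a functional assay on the whole organism with Rattus norvegicus as the target; on this read-out higher numbers stand for an effect only at larger amounts of compound and lower numbers for an effect already at smaller amounts. Compound 1 `NC(=O)/C=C1\CCc2ccc(Cl)cc21` gives 27 mg/kg. Compound 2 `CNC(=O)/C=C1\CCc2cc(F)c(F)cc21` gives 18 mg/kg. Compound 3 `O=C(/C=C1\CCc2ccc(F)cc21)Nc1ccccc1` gives 8 mg/kg, the lowest of the three numbers, with compound 2 the nearest and compound 1 the furthest, both gaps lying beyond the usual scatter. Each of these three differs from the others in more than one place, so no single change can be read off from them.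

Compound 4 `O=C(/C=C1\CCc2ccc(F)cc21)NC1CCCC1` differs from compound 3 in one place: cyclopentyl in place of phenyl on an amide-type nitrogen. For the measured compounds named here, no measured pair in this set shows what cyclopentyl in place of phenyl on an amide-type nitrogen does in this assay. Compounds 1 and 2, whose amide-type nitrogen carries no phenyl, give larger numbers than compound 3, but both differ from compound 3 elsewhere as well. The step is therefore expected to be small, toward a larger number if beyond the scatter at all, and for compound 4 the expected value is 12 mg/kg, between 5 mg/kg and 30 mg/kg. The step this estimate means is expected to be a 1.5-fold higher number from compound 3 to compound 4 (0.18 log units; within the scatter).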

Compound 4, dose for half-maximal effect: 14 mg/kg
Compound 4: the middle estimate sits 1.2-fold (0.07 log units) below what was measured; the range from low to high includes it.
By their numbers in this assay, from the lowest: compounds 3, 4, 2 and 1 (each within the scatter of the next, the first and the last beyond it).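

In this assay, for the compounds shown here, the only pair that differs in one place gives a clean reading (a 1.8-fold higher number from compound 3 to compound 4 (0.24 log units; within the scatter)), so phenyl and cyclopentyl on this amide-type nitrogen cannot be told apart. At this place on the shared core, a six-membered aromatic ring of carbon is therefore not required for a number in this range, since a five-membered non-aromatic ring of carbon reads the same within the scatter. Nothing available offers an explanation for this result.

Still open, from the compounds shown here alone, is how a benzyl group, a longer chain such as hexyl, or a ring carrying an amine or a carboxylic acid would read on this nitrogen. Going by these compounds, the steps from compound 1 and compound 2 cannot be read, as each differs from the others in more than one place, so the effect of removing the ring altogether also stays open.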